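A few compounds are considered here, and "the series" means these few. Any claim that something is new, unique, unknown or untested is made for them only; others in the source may bear on it.

Measured so far in an assay on CHO cells for displacement of a labelled ligand from adenosine receptor A3 (Homo sapiens), tested at 1 uM; on this read-out higher numbers stand for more inhibition at the one concentration tested (going by the name of the read-out) and lower numbers for less inhibition:
compound 1, `CC(=O)Nc1nn(-c2ccccc2)c(=O)c2ccccc12`, gives 0%
compound 2, `COc1ccc(C(=O)Nc2nn(-c3ccccc3)c(=O)c3ccccc23)cc1`, gives 10%

Compound 1 stands lowest of the two numbers; its nearest neighbour, compound 2, comes a number 10 percentage points higher from compound 1 to compound 2 (within the scatter). Compound 3, `Nc1nn(-c2ccccc2)c(=O)c2ccccc12`, differs from compound 1 by hydrogen in place of acetyl on a nitrogen on an aromatic ring. Going by the values given here, no measured step removes this group: the only step known, a number 10 percentage points higher from compound 1 to compound 2 (within the scatter), merely exchanges what sits on the carbonyl carbon and does not leave the scatter. The expected step to compound 3 is therefore a number 5 percentage points higher from compound 1 to compound 3 (within the scatter), nothing beyond the scatter. Compound 3 is estimated at 5%, in the range 0% to 20%.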

Compound 3, a percentage reported as inhibition, at one concentration (the size of the read-out at that concentration, not a potency): 8%
The estimate for compound 3 lay 3 percentage points below the measured number, within the range that was stated.
By their numbers in this assay, from the lowest: compounds 1, 3 and 2 (each within the scatter of the next).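

Hydrogen in place of acetyl on a nitrogen on an aromatic ring, acetamido to amino, gives a number 8 percentage points higher from compound 1 to compound 3 (within the scatter) in this assay. The earlier step only exchanged what sits on the carbonyl carbon; this one removes the acetyl group entirely, and at the one concentration tested that removal does not leave the scatter. No evidence bears on this result.

On these data alone, whether a longer alkyl chain or a carboxylic acid in place of acetyl on that nitrogen would move the number beyond the scatter remains open. As far as these compounds go, the effect of changes elsewhere on the core of compound 1 also remains open.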